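Ester to dimethylamide at the carbonyl of compound 1

The compounds below may be only part of what the source reports. "The series", "measured", "known", "first", "only" and "open" are said of these compounds alone.

Among the compounds with values here, compound 1 `COC(=O)C1=Cc2ccc(OC)cc2OC1c1cc(OC)c(OC)c(OC)c1` stands at the lower of the two numbers so far: in a functional assay for inhibition of nuclear factor NF-kappa-B complex (Homo sapiens) (a lower number here means a stronger inhibitor, a higher number a weaker inhibitor), compound 1 gives 13800 nM. Its ethyl counterpart compound 2 `CCOC(=O)C1=Cc2ccc(OC)cc2OC1c1cc(OC)c(OC)c(OC)c1` gives 25000 nM in this assay, and the step of a 1.8-fold higher number from compound 1 to compound 2 (0.26 log units; within the scatter) stays within the scatter. Compound 3 `COc1ccc2c(c1)OC(c1cc(OC)c(OC)c(OC)c1)C(C(=O)N(C)C)=C2` differs from compound 1 by dimethylamino in place of methoxy on a carbonyl carbon, read one bond further out as methoxycarbonyl to dimethylcarbamoyl. Within the data shown here, no measured step touches this change; the single step in hand, a 1.8-fold higher number from compound 1 to compound 2 (0.26 log units; within the scatter), only lengthens the ester alkyl and moves the number little, so there is no ground to expect a sizeable shift in either direction beyond the scatter in this assay. For compound 3 the expected value in this assay is 15000 nM, within 5000 nM to 45000 nM. The expected step is a 1.1-fold higher number from compound 1 to compound 3 (0.04 log units; within the scatter).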

Compound 3, half-maximal inhibitory concentration: > 50000 nM
Compound 3 ended at the assay's limit; the forecaster's own chance of this, stated with the estimate: 15%; middle value at least 3.3-fold (0.52 log units) away from the limit.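

At the carbonyl carbon, dimethylamino in place of methoxy gives an at least 3.6-fold higher number from compound 1 to compound 3 (0.55 log units; beyond the scatter) in this assay, so this position does not tolerate every exchange of the group on the carbonyl, which the ester step alone could not show. With dimethylamino in place of ethoxy the series gives an at least 2.0-fold higher number from compound 2 to compound 3 (0.30 log units; that floor lies within the scatter), so that floor alone does not separate the ethyl ester from the amide. The value of compound 3 is a limit and not a number, so both steps are floors and their true size stays unread: the limit of > 50000 nM in this assay, at which 1 of the 3 values shown sits.

The shown compounds hold only two esters and one dimethylamide, so it remains open whether the loss belongs to amides in general or to this one. On these data alone, a methylamide, a primary amide or a carboxylic acid on the same carbonyl carbon could stay near compound 1 or reach the limit, and a longer ester chain is equally open.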